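The compounds below may be only part of what the source reports. "The series", "measured", "known", "first", "only" and "open" are said of these compounds alone.

In a functional assay on NCI-H460 cells (Homo sapiens) for inhibition, read by CCK-8 assay, with a stated time of 48 h (on this read-out lower numbers stand for stronger inhibition and higher numbers for weaker inhibition), compound 1 `Cc1ccc(-c2nn(-c3ccccc3)cc2C(=O)NC(=S)Nc2ccc(Cl)cc2)cc1` gives 3650 nM, the lowest of the three numbers shown, though only within the scatter: compound 2 `Cc1ccc(NC(=S)NC(=O)c2cn(-c3ccccc3)nc2-c2ccc(C)cc2)cc1` gives 3760 nM and compound 3 `Cc1ccc(NC(=S)NC(=O)c2cn(-c3ccccc3)nc2-c2ccccc2)cc1` gives 3960 nM. The two measured steps, a 1.0-fold higher number from compound 1 to compound 2 (0.01 log units; within the scatter) and a 1.1-fold higher number from compound 2 to compound 3 (0.02 log units; within the scatter), each swap a small group on an aromatic carbon, and each leaves this assay essentially unchanged. Compound 4 `O=C(NC(=S)Nc1ccc(Cl)cc1)c1cn(-c2ccccc2)nc1-c1ccc(F)cc1` differs from compound 1 by fluoro in place of methyl on an aromatic carbon. This again swaps a small group on an aromatic carbon, so on the evidence of the two small steps seen so far the expected step in this assay is a 1.0-fold higher number from compound 1 to compound 4 (0.02 log units; within the scatter), none beyond the scatter. Compound 4 is therefore expected to give about 3800 nM, within 1800 nM to 8000 nM.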

Compound 4, half-maximal inhibitory concentration: 3090 nM
Beside the measured number, compound 4's estimate is 1.2-fold (0.09 log units) above it; the range from low to high includes it.
By their numbers in this assay, from the lowest: compounds 4, 1, 2 and 3 (each within the scatter of the next).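

Replacing 4-methylphenyl with 4-fluorophenyl gives a 1.2-fold lower number from compound 1 to compound 4 (0.07 log units; within the scatter) in this assay and so leaves the number within the scatter. Together with a 1.1-fold higher number from compound 2 to compound 3 (0.02 log units; within the scatter) at the same place, this shows that methyl, hydrogen and fluoro all give similar numbers on this ring, in two different compound pairs. No measurement shown here offers an explanation for this flat response.

From the compounds shown here alone, whether an amine, a carboxylic acid or a longer chain at this place would also leave the number unchanged remains open. So does whether any group here can move it beyond the scatter.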